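Cytotoxicity when carboxy replaces methoxy on the benzyl ring

The source may report more compounds than this note shows. Statements on the series, on what has been measured and on what is new or still open speak of the compounds shown alone.

Compound 1 `Cc1cc(/C=C2\SC(=S)N(c3ccccc3)C2=O)c(C)n1-c1ccc(O)c(C(=O)O)c1`: in an ADME assay on MT2 cells (Homo sapiens) for cytotoxicity, read by XTT assay, with a stated time of 4 days (on this read-out higher numbers stand for lower toxicity in this test and lower numbers for higher toxicity in this test), compound 1 reaches only the assay limit > 100000 nM.
Compound 2 `COc1cccc(CN2C(=O)/C(=C/c3cc(C)n(-c4ccc(O)c(C(=O)O)c4)c3C)SC2=S)c1`: in this assay compound 2 gives 102000 nM.

Compound 2 holds the only number shown in this assay. The other value shown is a limit (the limit of > 100000 nM in this assay, at which 1 of the 2 values shown sits). Compound 3 `Cc1cc(/C=C2\SC(=S)N(Cc3cccc(C(=O)O)c3)C2=O)c(C)n1-c1ccc(O)c(C(=O)O)c1` differs from compound 2 by carboxy in place of methoxy on an aromatic carbon. Within the data shown here, the single measured step, a step that the limit leaves unreadable from compound 1 to compound 2, cannot be read in size, so no measured step bears usefully on this change, and no shift beyond the scatter is expected. Compound 3 is therefore estimated at 100000 nM, within 50000 nM to 200000 nM, an expected step of a 1.0-fold lower number from compound 2 to compound 3 (0.01 log units; within the scatter).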

Compound 3, half-maximal cytotoxic concentration: > 100000 nM
Compound 3: no number, only a limit; the forecaster's own chance of this, stated with the estimate: 50%; the middle value sits exactly at the limit.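

In this assay compound 3 reaches only a limit, > 100000 nM, so the steps to it from compound 1 and compound 2 cannot be read in size. The compounds shown leave open whether carboxy in place of methoxy shifts this read-out at all: the limit of > 100000 nM in this assay, at which 2 of the 3 values shown sit.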